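Hydrazone aryl swap on a shared core

The source may hold more compounds than are shown below. What is called first, only, known or untested is meant among the compounds shown, and "the series" means these compounds.

compound 1 `CC1CCC(=NNc2cc(Cl)cc(Cl)c2)c2ncc(C(=O)O)c(=O)n21` — > 100 umol/kg
compound 2 `Cc1cccc(Cl)c1NN=C1CCC(C)n2c1ncc(C(=O)O)c2=O` — > 100 umol/kg

Of the compounds shown here, two have been tested in a functional assay on the whole organism with Rattus norvegicus as the target; a higher number here means that more compound is needed for the effect, a lower number that less compound is needed. For compound 1 the result is a limit of the assay, > 100 umol/kg. For compound 2 the result is likewise a limit, > 100 umol/kg. For the measured compounds named here, the only step between them, a step that the two limits leave unreadable from compound 1 to compound 2, therefore cannot be read; both of its ends sit at the limit of > 100 umol/kg in this assay, at which 2 of the 2 values shown sit. Compound 2 thus stands only at a limit in this assay, with no number behind it.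

Compound 3 `CC1CCC(=NNc2cc(Cl)ccc2O)c2ncc(C(=O)O)c(=O)n21` differs from compound 2 by 5-chloro-2-hydroxyphenyl in place of 2-chloro-6-methylphenyl on an amine nitrogen. No measured step bears on this change, and the one step shown is itself unreadable. With nothing to point in either direction, compound 3 is expected to give about 150 umol/kg in this assay, most likely reported again as a limit, with a range from 40 umol/kg to 600 umol/kg. The step that the limit leaves unreadable from compound 2 to compound 3 is accordingly expected to stay within the scatter.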

Compound 3, dose for 50% inhibition: > 100 umol/kg
Compound 3 ended at the assay's limit; the forecaster's own chance of this, stated with the estimate: 70%; the middle value is on the limit's open side.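

Compound 3 also ended at a limit in this assay, so its steps from compound 1 and compound 2 cannot be read: the limit of > 100 umol/kg in this assay, at which 3 of the 3 values shown sit. The compounds shown leave open whether any aryl group on the hydrazone of the shared core gives a measurable dose in this assay.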